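Swapping an Ether Chain for a Thioether on the Core

The compounds below may be only part of what the source reports. "The series", "measured", "known", "first", "only" and "open" are said of these compounds alone.

Of the compounds shown here, three sharing one core have been measured in an assay on cells for antagonist activity at transient receptor potential cation channel subfamily V member 1 (Homo sapiens), read by FLIPR and calcium flux, with a stated time of 6 min; on this read-out higher numbers stand for weaker inhibition and lower numbers for stronger inhibition. Compound 1 `CCOc1nc(C(C)(C)C)ccc1CNC(=O)C(C)c1ccc(NS(C)(=O)=O)c(F)c1` gives 14.8 nM. Compound 2 `CCCCOc1nc(C(C)(C)C)ccc1CNC(=O)C(C)c1ccc(NS(C)(=O)=O)c(F)c1` gives 0.9 nM, and compound 3 `COCCCOc1nc(C(C)(C)C)ccc1CNC(=O)C(C)c1ccc(NS(C)(=O)=O)c(F)c1` gives 5.6 nM. Compound 3 thus stands second highest of the three numbers; its nearest neighbour is compound 1, while compound 2 lies furthest from it. Compound 4 `CCCCCSc1nc(C(C)(C)C)ccc1CNC(=O)C(C)c1ccc(NS(C)(=O)=O)c(F)c1` differs from compound 3 by a single exchange: pentylsulfanyl in place of 3-methoxypropoxy on an aromatic carbon, on an aromatic carbon next to the ring nitrogen of the core. Among the compounds with values here, two measured steps bear on this change. Adding ethyl in place of hydrogen on the saturated chain gave a 16-fold lower number from compound 1 to compound 2 (1.22 log units; beyond the scatter), while putting methoxy in place of methyl at the chain end gave a 6.2-fold higher number from compound 2 to compound 3 (0.79 log units; beyond the scatter). Compound 4 carries the longer chain and lacks the methoxy, so in this assay a lower number is expected, towards the level of compound 2, estimated as a 3.7-fold lower number from compound 3 to compound 4 (0.57 log units; beyond the scatter). Compound 4 is therefore expected to give about 1.5 nM, within a range from 0.4 nM to 6 nM.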

Compound 4, inhibition constant: 3.1 nM
Compound 4: the middle estimate sits 2.1-fold (0.32 log units) below what was measured; low and high end bracket the measured number.
By their numbers in this assay, from the lowest: compound 2; then compounds 4 and 3 (each within the scatter of the next); then compound 1.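

In this assay the position tolerates a sulfur link: a 1.8-fold lower number from compound 3 to compound 4 (0.26 log units; within the scatter), so pentylsulfanyl and 3-methoxypropoxy cannot be told apart here. The other two steps place the thioether between the ethoxy and butoxy chains, with a 4.8-fold lower number from compound 1 to compound 4 (0.68 log units; beyond the scatter) and a 3.4-fold higher number from compound 2 to compound 4 (0.54 log units; beyond the scatter), so this sulfur-linked chain improves on ethoxy but does not match butoxy. No supporting evidence is available to explain these differences.

Pentylsulfanyl differs from butoxy in both its linking atom and its chain, so the effect of sulfur cannot be separated from that of chain length. A butylsulfanyl or pentyloxy chain would separate the two, while an amine link at this position would show whether the link must be oxygen or sulfur at all.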